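Furan-3-yl in place of 4-methoxyphenyl on the shared core

The source may hold more compounds than are shown below. What is called first, only, known or untested is meant among the compounds shown, and "the series" means these compounds.

In a functional assay on K562 cells (Homo sapiens) for antiproliferative activity, with a stated time of 72 h (on this read-out higher numbers stand for weaker inhibition and lower numbers for stronger inhibition), compound 1 `Nc1ncnn2c([C@@H]3O[C@H](CO)[C@@H](O)[C@H]3O)cc(C#Cc3ccc(F)cc3)c12` gives > 100000 nM, which is a limit and not a number. Within the data shown here, compound 2 `COc1ccc(-c2cc([C@@H]3O[C@H](CO)[C@@H](O)[C@H]3O)n3ncnc(N)c23)cc1` gives 76400 nM, the only true number so far, so it has no measured neighbour to be ranked against. Compound 3 `Nc1ncnn2c([C@@H]3O[C@H](CO)[C@@H](O)[C@H]3O)cc(-c3ccoc3)c12` has not been measured. It differs from compound 2 by furan-3-yl in place of 4-methoxyphenyl on an aromatic carbon, with furan-3-yl in place of 4-methoxyphenyl on an aromatic carbon. Among the measured compounds shown here, one measured step bears on this place: an at least 1.3-fold lower number from compound 1 to compound 2 (0.11 log units; that floor lies within the scatter). That step is a weak guide, so the expectation rests mostly on the change itself, and a modest move towards stronger inhibition is expected, held loosely. The expected step is a 3.1-fold lower number from compound 2 to compound 3 (0.49 log units; beyond the scatter). For compound 3 the estimated value is 25000 nM, with an expected range of 2000 nM to 100000 nM.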

Compound 3, half-maximal inhibitory concentration: 2100 nM
Compound 3: the middle estimate sits 12-fold (1.08 log units) above what was measured, and the stated range covers the measured number.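

At this aromatic carbon of the shared core, the group carried there clearly matters in this assay: furan-3-yl in place of 4-methoxyphenyl gives a 36-fold lower number from compound 2 to compound 3 (1.56 log units; beyond the scatter). Furan-3-yl in place of 2-(4-fluorophenyl)ethynyl gives an at least 47-fold lower number from compound 1 to compound 3 (1.67 log units; beyond the scatter), while the floor of the step between the two larger groups lay within the scatter. Compound 1 has only a limit here and not a number: the limit of > 100000 nM in this assay, at which 1 of the 3 values shown sits.

As far as these compounds go, whether the gain would hold with an unsubstituted phenyl, a thiophen-3-yl or a furan-2-yl stays open, as does what a plain methyl or a small amine would give on this carbon. From the compounds shown here alone, the 3,4-dihydroxy-5-(hydroxymethyl)oxolan-2-yl group is the same in all three compounds, so its part in the read-out also stays open.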